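The source may report more compounds than this note shows. Statements on the series, on what has been measured and on what is new or still open speak of the compounds shown alone.

In an in vitro functional assay on HEK285-7 cells for antagonist activity at prostaglandin D2 receptor 2 (Homo sapiens), read by BRET and beta-arrestin recruitment (on this read-out lower numbers stand for smaller maximal responses and higher numbers for larger maximal responses), three compounds of a shared core have been measured. Compound 1 `O=C(O)Cc1sc(Cc2ccccc2)nc1-c1ccc(Cl)cc1` gives 50%, and compound 3 `O=C(O)Cc1sc(NC(=O)c2ccccc2)nc1-c1ccc(Cl)cc1` gives 50%. Compound 2 `N#Cc1ccc(-c2nc(C(c3ccc(F)cc3)c3ccc(F)cc3)sc2CC(=O)O)cc1` gives 30%, the lowest of the three numbers; its value lies under those of compound 1 and of compound 3 by a gap that is beyond the usual scatter, while compound 1 and compound 3 show the same number.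

Compound 4 `O=C(O)Cc1sc(C(c2ccc(F)cc2)c2ccc(F)cc2)nc1-c1ccoc1` is the next compound and has not yet been measured in this assay. It differs from compound 2 in one place: furan-3-yl in place of 4-cyanophenyl on an aromatic carbon. Going by the values given here, no single-point step between measured compounds is available, so this change cannot be read against a precedent in the set. Since compound 2 sits at the low end of the three numbers, with compound 1 and compound 3 both higher, a rise in this assay is expected rather than a fall. The step from compound 2 to compound 4 is estimated at a number 15 percentage points higher from compound 2 to compound 4 (beyond the scatter) in this assay. Compound 4 is therefore expected to give about 45%, within a range of 25% to 70%.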

Compound 4, largest response reached (reported as efficacy), in percent of the reference or control that the assay uses: 80%
Beside the measured number, compound 4's estimate is 35 percentage points below it; measured number outside the range, above it.
By their numbers in this assay, from the lowest: compound 2; then compounds 1 and 3 (each within the scatter of the next); then compound 4.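

In this assay, going by these compounds alone, the step for furan-3-yl in place of 4-cyanophenyl is a number 50 percentage points higher from compound 2 to compound 4 (beyond the scatter), the first change in a single place that can be read in this set. It shows that the group on this aromatic carbon, next to the ring nitrogen and next to the ring atom that bears a carboxymethyl group, can by itself shift the maximal response strongly while the rest of the molecule stays the same. No measurement shown accounts for the size of this step.

This single change swaps a six-membered ring carrying a nitrile for a five-membered ring with one oxygen, so it leaves open which of these differences matters, and an unsubstituted phenyl or a thiophen-3-yl group would help separate them. It also leaves open whether furan-3-yl would give a similar step on the core of compound 1.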